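The compounds below may be only part of what the source reports. "The series", "measured", "known", "first", "only" and "open" are said of these compounds alone.

Working notes on the series. Four compounds share one core and differ only in the aryl group on the saturated ring carbon. In an assay on isolated protein for inhibition of protein kinase C zeta type (Homo sapiens), with a stated time of 4 min (a lower number here means a stronger inhibitor, a higher number a weaker inhibitor), compound 1 `CC(C)(C)C1=NN(c2ccc(Cl)cc2)C(c2ccc(Br)cc2)C1` gives "not determined" (no result reported). Compound 2 `CC(C)(C)C1=NN(c2ccc(Cl)cc2)C(c2cccc(O)c2)C1` gives 5300 nM in this assay. Compound 3 `CC(C)(C)C1=NN(c2ccc(Cl)cc2)C(c2ccc(O)c(F)c2)C1` gives 3800 nM in this assay. Among the measured compounds shown here, the step of a 1.4-fold lower number from compound 2 to compound 3 (0.14 log units; within the scatter) lies within the scatter, so compound 3 and compound 2 cannot be separated on the numbers so far, and compound 1 adds no number to compare against.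

Compound 4 `CC(C)(C)C1=NN(c2ccc(Cl)cc2)C(c2ccc(O)c(Cl)c2)C1` differs from compound 3 by chloro in place of fluoro on an aromatic carbon. For the measured compounds named here, no measured step in this assay exchanges one halogen for another on that ring; the only measured step, a 1.4-fold lower number from compound 2 to compound 3 (0.14 log units; within the scatter), replaces the whole aryl group and still stays within the scatter. A step beyond the scatter is therefore not expected for this smaller exchange, and the expectation rests on compound 3 at 3800 nM. Compound 4 is expected to give about 3500 nM in this assay, in the range 1500 nM to 8000 nM. The expected step is a 1.1-fold lower number from compound 3 to compound 4 (0.04 log units; within the scatter).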

Compound 4, half-maximal inhibitory concentration: 700 nM
Beside the measured number, compound 4's estimate is 5.0-fold (0.70 log units) above it; the measured number lies below the stated range.
By their numbers in this assay, from the lowest: compound 4; then compounds 3 and 2 (each within the scatter of the next).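

In this assay the group on the aromatic carbon ortho to a hydroxy group matters: chloro in place of fluoro gives a 5.4-fold lower number from compound 3 to compound 4 (0.73 log units; beyond the scatter) from the exchange of a single heavy atom, with no change in the counted hydrogen-bond donors or acceptors. The exchange of the whole aryl group, which stayed within the scatter with the fluoro group, now separates with the chloro group: 3-chloro-4-hydroxyphenyl in place of 3-hydroxyphenyl gives a 7.6-fold lower number from compound 2 to compound 4 (0.88 log units; beyond the scatter) on the saturated ring carbon. Nothing available accounts for the difference between chloro and fluoro at this position.

Going by these compounds, whether a bromo, methyl or methoxy group at this position would lower the number further stays open. Also open, on these data alone, is whether the hydroxy group is still required with chloro in place, or could give way to a methoxy group or an amine.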